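The compounds below may be only part of what the source reports. "The series", "measured", "known", "first", "only" and "open" are said of these compounds alone.

Three compounds have been measured in an assay on HEK293 cells for agonist activity at Toll-like receptor 8 (Homo sapiens), read by a luciferase reporter, with a stated time of 6 h; on this read-out lower numbers stand for an effect already at smaller amounts and higher numbers for an effect only at larger amounts of compound:
Compound 1, `CCCCNc1nc(N)nc2ccn(CCCc3ccccc3)c12`, gives 3.78 uM.
Compound 2, `CCCCNc1nc(N)nc2ccn(CC=C(C)C)c12`, gives only the limit of the assay, > 25 uM.
Compound 3, `CCCCNc1nc(N)nc2ccn(Cc3cn4ccccc4n3)c12`, likewise gives only the limit of the assay, > 25 uM.

Compound 2 thus sits at the limit of > 25 uM in this assay, at which 2 of the 3 values shown sit, and no number is known for it. Among the measured compounds shown here, compound 1 is the only compound here with a measured number. For the measured compounds named here, the one measured step, an at least 6.6-fold higher number from compound 1 to compound 2 (0.82 log units; beyond the scatter), shows that changing the group on the saturated chain carbon bound to the aromatic nitrogen can push the read-out out of the measurable range.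

Compound 4, `CCCCNc1nc(N)nc2ccn(Cc3ccncc3)c12`, is not yet measured. It differs from compound 2 in one place: pyridin-4-yl in place of 2-methylprop-1-en-1-yl on a saturated chain carbon bound to an aromatic nitrogen. Going by the values given here, no measured step starts from compound 2, so the expectation rests on neighbours. Compound 3 also carries an aromatic ring on the saturated chain carbon bound to the aromatic nitrogen and sits at the limit. Compound 1 carries its phenyl on a longer chain and gives a number. A step of an at least 1.2-fold lower number from compound 2 to compound 4 (0.09 log units; that floor lies within the scatter) is therefore expected, with no clear direction beyond the scatter and most likely ending at another limit. Compound 4 is expected to give about 20 uM, between 5 uM and 60 uM, with a fair chance that only a limit is reported.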

Compound 4, minimum effective concentration: > 25 uM
Compound 4 gave a limit, no number (the forecaster's own chance of this, stated with the estimate: 60%); at least 1.2-fold (0.09 log units) between middle value and limit.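

Compound 4 shows that an aromatic ring near the aromatic nitrogen does not by itself give a measurable number in this assay: (pyridin-4-yl)methyl ends at a limit, just as the open-chain 3-methylbut-2-en-1-yl of compound 2 does. Pyridin-4-yl in place of phenethyl gives an at least 6.6-fold higher number from compound 1 to compound 4 (0.82 log units; beyond the scatter), so compound 1 remains the only compound here with a measured number. The step between the two limits cannot be read, and most of this series now sits at one end of the scale: the limit of > 25 uM in this assay, at which 3 of the 4 values shown sit.

On these data alone, it remains open whether the phenyl ring or the longer chain of compound 1 matters more, which a benzyl group or a 3-(pyridin-4-yl)propyl chain at this position could help separate. As far as these compounds go, how a chain ending in an amine would read also remains open.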